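The compounds below may be only part of what the source reports. "The series", "measured", "known", "first", "only" and "open" are said of these compounds alone.

Compound 1, with structure `Cc1nc(-c2ccc(Cl)cc2)sc1C(=O)CSc1nc(-c2ccc(Cl)c(Cl)c2)c(C#N)c(=O)[nH]1`, is the reference point here. Among the compounds with values here, in a functional assay on U-87MG ATCC cells for antiproliferative activity against U-87 MG (Homo sapiens), read by MTT assay, with a stated time of 48 h, tested at 5 uM (a higher number here means a weaker effect of the compound at the concentration tested, a lower number a stronger effect), compound 1 gives 101%, the highest of the three numbers so far, although the two companions sit within the usual scatter of it. Compound 3, with structure `Cc1nc(-c2ccc(Cl)cc2)sc1C(=O)CSc1nc(-c2ccc(Cl)cc2)c(C#N)c(=O)[nH]1`, gives 99%, and compound 2, with structure `COc1ccc(-c2nc(SCC(=O)c3sc(-c4ccc(Cl)cc4)nc3C)[nH]c(=O)c2C#N)cc1`, gives 92.1%. The step of a number 2 percentage points lower from compound 1 to compound 3 (within the scatter) and the step of a number 8.9 percentage points lower from compound 1 to compound 2 (within the scatter) both stay inside the scatter, so none of the three can be called stronger or weaker than another.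

Compound 4, with structure `Cc1nc(-c2ccccc2)sc1C(=O)CSc1nc(-c2ccc(Cl)c(Cl)c2)c(C#N)c(=O)[nH]1`, differs from compound 1 by hydrogen in place of chloro on an aromatic carbon. The closest measured guide is the step from compound 1 to compound 3, which also swaps a chloro for hydrogen on an aromatic carbon, though on the other aryl group, and that step was a number 2 percentage points lower from compound 1 to compound 3 (within the scatter). Since that comparable change moved the read-out by only a few points, no step beyond the scatter is expected for a number 2 percentage points lower from compound 1 to compound 4 (within the scatter). Compound 4 is therefore estimated at 99%, with a plausible range from 88% to 108%.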

Compound 4, a percentage reported as activity, at one concentration (the size of the read-out at that concentration, not a potency): 98.6%
Compound 4: the middle estimate sits 0.4 percentage points above what was measured; the range from low to high includes it.
By their numbers in this assay, from the lowest: compounds 2, 4, 3 and 1 (each within the scatter of the next).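

Within the data shown here, this is the first change at this position: 4-chlorophenyl to phenyl, on the ring carbon para to a large group, gives a number 2.4 percentage points lower from compound 1 to compound 4 (within the scatter) in this assay. The earlier hydrogen-for-chloro step changed the other aryl group, so compound 4 adds that the chloro at this second position can also be replaced by hydrogen without a difference that can be read at this single concentration. Nothing available explains this outcome or tells what this chloro does in the cells.

The compounds shown leave open whether a larger or very different group at this position, such as an amine, a carboxylic acid or a longer chain, would separate from compound 1 in this assay. They also leave open whether compound 1 and compound 4 would still match at another concentration.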